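Hydroxamic acid series: amine swap from compound 3 to compound 4

The compounds below may be only part of what the source reports. "The series", "measured", "known", "first", "only" and "open" are said of these compounds alone.

Measured compounds:
compound 1 `O=C(NO)c1ccc(-c2nc(N3CCCC3)c3ccccc3n2)cc1`, 57.2%
compound 2 `COc1cc(OC)c2c(N3CCC(F)(F)CC3)nc(-c3ccc(C(=O)NO)cc3)nc2c1`, 53.2%
compound 3 `O=C(NO)c1ccc(-c2nc(N3CCCC3)c3ccc(Cl)cc3n2)cc1`, 54.6%

In an assay on isolated protein for inhibition of protein deacetylase HDAC6 (Homo sapiens), tested at 0.5 uM (a lower number here means less inhibition, a higher number more inhibition at the concentration tested (going by the name of the read-out)), compound 1 gives 57.2%, compound 2 gives 53.2% and compound 3 gives 54.6%. Within the data shown here, compound 3 stands second highest of the three, but all gaps are within the scatter; the one single-point step, a number 2.6 percentage points lower from compound 1 to compound 3 (within the scatter), concerns a different position. Compound 4 `CN1CCN(c2nc(-c3ccc(C(=O)NO)cc3)nc3cc(Cl)ccc23)CC1` differs from compound 3 by 4-methylpiperazin-1-yl in place of pyrrolidin-1-yl on an aromatic carbon. Among the measured compounds shown here, no measured step addresses this change. Compound 2, which carries a six-membered amine at the same place among other differences, gives a value within the scatter of compound 3. The step is therefore expected to be a number 2.6 percentage points lower from compound 3 to compound 4 (within the scatter), nothing beyond the scatter. Compound 4 is estimated at 52%, range 38% to 66%.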

Compound 4, a percentage reported as inhibition, at one concentration (the size of the read-out at that concentration, not a potency): 94.4%
Beside the measured number, compound 4's estimate is 42.4 percentage points below it; measured number outside the range, above it.
By their numbers in this assay, from the lowest: compounds 2, 3 and 1 (each within the scatter of the next); then compound 4.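

In this assay, the amine position is the only place among the compounds shown where a single change goes beyond the scatter: 4-methylpiperazin-1-yl in place of pyrrolidin-1-yl gives a number 39.8 percentage points higher from compound 3 to compound 4 (beyond the scatter) on this aromatic carbon. The other single-place step, chloro in place of hydrogen, stayed within the scatter, so the read-out responds far more to this amine swap. Nothing at hand explains the step.

Open, as far as these compounds go, is whether the gain follows the extra ring nitrogen or its methyl, and whether it holds on the core of compound 1, which lacks the chloro. Piperazin-1-yl without the methyl and morpholin-4-yl at this carbon would separate these.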